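From diethylamino to phenyl on the shared core

A few compounds are considered here, and "the series" means these few. Any claim that something is new, unique, unknown or untested is made for them only; others in the source may bear on it.

Three related compounds have been taken to an ADME assay on BJ cells (Homo sapiens) for cytotoxicity, with a stated time of 72 h; a higher number here means that more compound is needed for the effect, a lower number that less compound is needed. Compound 1 (`COc1cc2ncnc(-n3nc(-c4ccccn4)nc3N)c2cc1[N+](=O)[O-]`) gives > 13000 nM, which is a limit of the assay and not a number. For compound 2 (`Nc1nc(-c2ccccn2)nn1-c1ncnc2cc(N3CCNCC3)c([N+](=O)[O-])cc12`) the entry reads "not determined" (no result reported). Compound 3 (`CCN(CC)c1nc(-n2nc(-c3ccccn3)nc2N)c2cc(OC)c(OC)cc2n1`) gives > 9000 nM, which is also a limit and not a number. Compound 3 therefore has no exact position on the scale, and neither of the other two measured compounds has a single number to compare it with.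

Compound 4 (`COc1cc2nc(-c3ccccc3)nc(-n3nc(-c4ccccn4)nc3N)c2cc1OC`) has not yet been measured. It carries phenyl in place of diethylamino on an aromatic carbon, between two ring nitrogen atoms: phenyl in place of diethylamino on an aromatic carbon. Going by the values given here, no measured pair shows the effect of a single change here. The expected step that the limit leaves unreadable from compound 3 to compound 4 lies within the usual scatter, with no clear direction. This expectation rests on compound 3, whose > 9000 nM is a limit. The estimated value for compound 4 is 10000 nM, with an expected range of 3000 nM to 30000 nM.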

Compound 4, half-maximal effective concentration: > 27000 nM
Compound 4: no number, only a limit (the forecaster's own chance of this, stated with the estimate: 60%); middle value at least 2.7-fold (0.43 log units) away from the limit.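

Compound 3 gives > 9000 nM, which is a limit and not a number. Going by these compounds alone, compound 4 gives > 27000 nM, also a limit, so no step between these two compounds can be read. The compounds shown leave open how much of either is needed for the effect, and whether phenyl in place of diethylamino changes that amount.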